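Shortening the Chain and Adding a Hydroxyl on a Phenol

This account rests on a few compounds, and the source may have more. Where it says the series, first, only, none or still open, it means among the compounds named here.

Measured so far in an assay on isolated protein for inhibition of leukotriene B4 receptor 1 (Homo sapiens), tested at 10 uM; on this read-out lower numbers stand for less inhibition and higher numbers for more inhibition at the one concentration tested (going by the name of the read-out):
compound 1 `C=CCc1cc(C(C)=O)c(O)cc1OCCCCCC#N` gives 81%
compound 2 `C=CCc1cc(C(C)=O)c(O)cc1OCCCCCCCCCCC#N` gives 50%
compound 3 `C=CCc1cc(C(C)=O)c(O)cc1OCCCCCCC` gives 31%

Compound 3 stands lowest of the three; compound 2 lies closest to it and compound 1 furthest. Compound 4 `C=CCc1cc(C(C)=O)c(O)cc1OCCCCO` differs from compound 3 by hydroxy in place of propyl on a saturated chain carbon, four bonds along the chain from an oxygen on an aromatic ring. Within the data shown here, two measured steps bear on this: a number 50 percentage points lower from compound 1 to compound 3 (beyond the scatter) and a number 19 percentage points lower from compound 2 to compound 3 (beyond the scatter), both running the other way, from a chain carrying a polar end group to a plain hydrocarbon chain. Reversing that kind of change, the step of a number 29 percentage points higher from compound 3 to compound 4 (beyond the scatter) is expected to be large and upward in this assay, though the exchange of nitrile for hydroxy is untested. Compound 4 is therefore estimated at 60%, with a range from 35% to 85%.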

Compound 4, a percentage reported as inhibition, at one concentration (the size of the read-out at that concentration, not a potency): 48%
For compound 4 the middle estimate is 12 percentage points above the measured one, within the range that was stated.
By their numbers in this assay, from the lowest: compound 3; then compounds 4 and 2 (each within the scatter of the next); then compound 1.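

In this assay, among these compounds, hydroxy at the chain end gives a number 17 percentage points higher from compound 3 to compound 4 (beyond the scatter), so a nitrile is not the only end group that stands above the plain hydrocarbon chain. Hydroxy does not reach the nitrile of compound 1, with a number 33 percentage points lower from compound 1 to compound 4 (beyond the scatter), and it cannot be told apart from the long nitrile chain, with a number 2 percentage points lower from compound 2 to compound 4 (within the scatter). No measurement offered here accounts for these steps. Still open, as far as these compounds go, is how an amine or a carboxylic acid would read in the same place. Also open, from the compounds shown here alone, is whether hydroxy on a longer chain would follow the nitrile chains.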